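This account rests on a few compounds, and the source may have more. Where it says the series, first, only, none or still open, it means among the compounds named here.

Compound 1 `CC(C)(C)OC(=O)Nc1ncc(C(Oc2cccc(C#N)c2)c2ccc(Cl)cc2)s1`: > 50000 nM
Compound 2 `O=C(Nc1ncc(C(Oc2ccc3cc(Br)ccc3c2)c2ccc(Cl)cc2)s1)C1CC1`: "not toxic" (no number reported)
Compound 3 `CC(=O)O[C@@H]1OC(C(=O)Nc2ncc(C(Oc3ccc4cc(Br)ccc4c3)c3ccc(Cl)cc3)s2)[C@@H](OC(C)=O)[C@@H](OC(C)=O)[C@H]1OC(C)=O`: "not toxic" (no number reported)

All three compounds were examined in an ADME assay on HepG2 2.2.15 cells (Homo sapiens) for cytotoxicity; a lower number here means that less compound is tolerated, a higher number that more compound is tolerated. For compound 1 the value > 50000 nM is a limit of this assay and not a number. Compound 2 is recorded as "not toxic" (no number reported), an entry without a single number. Compound 3 is likewise recorded as "not toxic" (no number reported). Compound 2 therefore stands among entries none of which gives a number: one of the three sits at the limit of > 50000 nM in this assay, at which 1 of the 3 values shown sits, and the other two carry only a word. Among the compounds with values here, no step between measured compounds that differ in one place is available, so no measured size of change in this assay can be quoted.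

Compound 4 `O=S(=O)(Nc1ncc(C(Oc2ccc3cc(Br)ccc3c2)c2ccc(Cl)cc2)s1)c1ccccc1` has not yet been measured. It differs from compound 2 in one place: phenylsulfonyl in place of cyclopropylcarbonyl on a nitrogen on an aromatic ring. With every measured compound tolerated up to the reported boundary, the step from compound 2 to compound 4 is expected to be none beyond the scatter in this assay, with compound 4 again tolerated at high concentration. Compound 4 is estimated to give 50000 nM in this assay, within a range from 20000 nM to 100000 nM, and most likely the result will again be reported only as a limit.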

Compound 4, half-maximal cytotoxic concentration: > 50000 nM
Compound 4: only a limit was reported (the forecaster's own chance of this, stated with the estimate: 70%); the middle value lies on the limit itself.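

In this assay compound 4 gives > 50000 nM, which is a limit of the assay and not a number. Within the data shown here, compound 2 carries the entry "not toxic" (no number reported), so no step between compound 2 and compound 4 can be read. The compounds shown leave open at what concentration any of them becomes toxic, and whether phenylsulfonyl and cyclopropylcarbonyl differ at all in this respect: the limit of > 50000 nM in this assay, at which 2 of the 4 values shown sit.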